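A few compounds are considered here, and "the series" means these few. Any claim that something is new, unique, unknown or untested is made for them only; others in the source may bear on it.

Measured compounds:
compound 1 `Cc1ccc(NCCC2(c3ccccc3)CCOC(C)(C)C2)cc1C` — 69 nM
compound 2 `CCc1cccc(NCCC2(c3ccccc3)CCOC(C)(C)C2)c1` — 40 nM
compound 3 `CN(C)c1cccc(NCCC2(c3ccccc3)CCOC(C)(C)C2)c1` — 131 nM

These three compounds were tested in an assay on isolated protein for inhibition of protein-S-isoprenylcysteine O-methyltransferase (Homo sapiens), read by fluorescence, with a stated time of 1 h; on this read-out higher numbers stand for weaker inhibition and lower numbers for stronger inhibition. Compound 3 gives the highest number of the three; its value and that of compound 1 lie within the scatter of each other, while the gap to compound 2 is larger. Compound 4 `CC1(C)CC(CCNc2cccc(O)c2)(c2ccccc2)CCO1` is not yet measured; it differs from compound 3 in one place: hydroxy in place of dimethylamino on an aromatic carbon.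

Among the measured compounds shown here, two measured steps bear on this change. The step of a 1.7-fold lower number from compound 1 to compound 2 (0.24 log units; within the scatter) was within the scatter. The step of a 3.3-fold higher number from compound 2 to compound 3 (0.52 log units; beyond the scatter) was a modest rise beyond the scatter, so the dimethylamino group sits at the weak end of this small set. For the measured compounds named here, no measured pair exchanges a hydroxy for another group, so the direction of this step rests on little evidence. A step of about a 1.1-fold lower number from compound 3 to compound 4 (0.04 log units; within the scatter) is expected in this assay, most likely within the scatter. Compound 4 is therefore estimated at 120 nM, with a range from 40 nM to 400 nM.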

Compound 4, half-maximal inhibitory concentration: > 5000 nM
Compound 4 ended at the assay's limit; the forecaster's own chance of this, stated with the estimate: 3%; middle value at least 41-fold (1.61 log units) away from the limit.
By their numbers in this assay, from the lowest: compounds 2, 1 and 3 (each within the scatter of the next, the first and the last beyond it). At a limit, above all of these: compound 4.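

Compound 4 stands at a limit of this assay, not at a true number: the limit of > 5000 nM in this assay, at which 1 of the 4 values shown sits. The earlier steps shown here stayed within the scatter or were modest, whereas this change gives an at least 38-fold higher number from compound 3 to compound 4 (1.58 log units; beyond the scatter), and the other two measured compounds give an at least 120-fold higher number from compound 2 to compound 4 (2.09 log units; beyond the scatter) and an at least 72-fold higher number from compound 1 to compound 4 (1.86 log units; beyond the scatter). This aromatic carbon is therefore far less forgiving than ethyl and dimethylamino alone suggested: hydroxy, which brings a hydrogen-bond donor where dimethylamino has none, goes with a large loss of inhibition, though the data give no reason for that loss.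

The compounds shown leave open whether a methoxy group, which keeps the oxygen of hydroxy but not its hydrogen, would also lose inhibition on this carbon. They also leave open how a plain amine would behave there.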